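Compound 3 to compound 4: sulfonyl aryl swap

The compounds below may be only part of what the source reports. "The series", "measured", "known", "first", "only" and "open" are said of these compounds alone.

Values in an ADME assay on HEK-293T cells (Homo sapiens) for cytotoxicity, read by MTT assay, with a stated time of 24 h; on this read-out lower numbers stand for higher toxicity in this test and higher numbers for lower toxicity in this test:
- compound 1 `Cc1ccc(-c2nn(-c3ccccc3)cc2-c2nc3ccccc3n2S(=O)(=O)c2ccc(F)cc2)cc1`: 128000 nM
- compound 2 `O=S(=O)(c1ccccc1)n1c(-c2cn(-c3ccccc3)nc2-c2ccc(F)cc2)nc2ccccc21`: 96300 nM
- compound 3 `Cc1ccc(C)c(S(=O)(=O)n2c(-c3cn(-c4ccccc4)nc3-c3ccc(F)cc3)nc3ccccc32)c1`: 54200 nM
- compound 4 `O=S(=O)(c1ccc(F)cc1)n1c(-c2cn(-c3ccccc3)nc2-c2ccc(F)cc2)nc2ccccc21`: not yet measured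

Compound 3 stands below compound 1 by more than the scatter and level with compound 2 within the scatter. The move to compound 4 makes one change, 4-fluorophenyl in place of 2,5-dimethylphenyl on a sulfonyl sulfur. For the measured compounds named here, the only measured step at this place is a 1.8-fold lower number from compound 2 to compound 3 (0.25 log units; within the scatter), which stays within the scatter and brings in the group that compound 4 gives up. Compound 1 also carries 4-fluorophenyl on a sulfonyl sulfur, but it differs from compound 4 elsewhere, so its number is only loose support. In this assay a small move toward a higher number is therefore expected, not clearly beyond the scatter. The expected step is a 1.7-fold higher number from compound 3 to compound 4 (0.22 log units; within the scatter). For compound 4 the estimate is 90000 nM, with an expected range of 48000 nM to 165000 nM.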

Compound 4, half-maximal cytotoxic concentration: 218000 nM
Beside the measured number, compound 4's estimate is 2.4-fold (0.38 log units) below it; measured number outside the range, above it.
By their numbers in this assay, from the lowest: compounds 3, 2, 1 and 4 (each within the scatter of the next, the first and the last beyond it).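

In this assay, for the compounds shown here, this position now shows a step beyond the scatter: a 4.0-fold higher number from compound 3 to compound 4 (0.60 log units; beyond the scatter) comes with 4-fluorophenyl in place of 2,5-dimethylphenyl on a sulfonyl sulfur, whereas the only earlier step here stayed within it. Fluoro in place of hydrogen on an aromatic carbon gives a 2.3-fold higher number from compound 2 to compound 4 (0.35 log units; beyond the scatter) and is also beyond the scatter, while fluoro in place of methyl on an aromatic carbon elsewhere in the molecule gives a 1.7-fold higher number from compound 1 to compound 4 (0.23 log units; within the scatter) and stays within it. Nothing available explains why these numbers differ.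

Open, on these data alone, is whether this step is particular to fluoro or would also appear with chloro or methoxy on the same ring. Also open, as far as these compounds go, is how the read-out responds when an alkyl chain or an amine replaces the aryl group on the sulfonyl sulfur.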